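The compounds below may be only part of what the source reports. "The series", "measured", "known", "first", "only" and "open" are said of these compounds alone.

Three compounds in this series were tested in a functional assay on A549 cells (Homo sapiens) for inhibition, read by CCK-8 assay, with a stated time of 72 h, tested at 1 uM; a higher number here means a stronger effect of the compound at the concentration tested, a lower number a weaker effect. Compound 1, `CN(C)C(=O)c1cc2cnc(Nc3ccc(S(=O)(=O)NCCCCCCN=C=S)cc3)nc2n1C1CCCC1`, gives 49.5%. Compound 2, `CN(C)C(=O)c1cc2cnc(Nc3ccc(S(=O)(=O)NCCCCCCCN=C=S)cc3)nc2n1C1CCCC1`, differs from it in one place: a group of 4 heavy atoms (2 carbon, 1 nitrogen, 1 sulfur; no ring) in place of a group of 3 heavy atoms (1 carbon, 1 nitrogen, 1 sulfur; no ring), on a saturated chain carbon, six bonds along the chain from a sulfonamide nitrogen. In this assay compound 2 gives 32.6%. This change lowered the read-out, with a number 16.9 percentage points lower from compound 1 to compound 2 (beyond the scatter), a step that lies beyond the scatter of the measurement.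

Compound 3, `CN(C)C(=O)c1cc2cnc(Nc3ccc(C(=O)NCCCCCN=C=S)cc3F)nc2n1C1CCCC1`, is built on a different core, and the difference between its core and that of compound 1 is not broken down here. In this assay compound 3 gives -1.6%, the lowest of the three numbers, standing beyond the scatter below both compound 2 and compound 1.

Compound 4, `CN(C)C(=O)c1cc2cnc(Nc3ccc(C(=O)NCCCCCCN=C=S)cc3F)nc2n1C1CCCC1`, has not yet been measured. It differs from compound 3 by a group of 4 heavy atoms (2 carbon, 1 nitrogen, 1 sulfur; no ring) in place of a group of 3 heavy atoms (1 carbon, 1 nitrogen, 1 sulfur; no ring), on a saturated chain carbon, five bonds along the chain from an amide-type nitrogen. Among the measured compounds shown here, this is the same kind of change as the one from compound 1 to compound 2, not the same change: in the earlier pair the chain grew at a saturated chain carbon six bonds along the chain from a sulfonamide nitrogen, whereas here it grows at a saturated chain carbon five bonds along the chain from an amide-type nitrogen. For the measured compounds named here, because the only measured precedent is a number 16.9 percentage points lower from compound 1 to compound 2 (beyond the scatter), the lengthening is not expected to raise the read-out by much, but compound 3 already sits near zero, so little room remains below it. Compound 4 is therefore expected to stay close to compound 3, with an estimated step of a number 6.6 percentage points higher from compound 3 to compound 4 (within the scatter). The estimate for compound 4 in this assay is 5%, with a range from -15% to 30%.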

Compound 4, a percentage reported as inhibition, at one concentration (the size of the read-out at that concentration, not a potency): -11.8%
Beside the measured number, compound 4's estimate is 16.8 percentage points above it, and the stated range covers the measured number.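

In this assay the longer chain gave a number 10.2 percentage points lower from compound 3 to compound 4 (beyond the scatter), so on the core of compound 3 the change pushed the read-out the same way as on the core of compound 1, and the two steps cannot be told apart in size: the same change on two cores in this assay, a number 16.9 percentage points lower (beyond the scatter) from compound 1 to compound 2 and a number 10.2 percentage points lower (beyond the scatter) from compound 3 to compound 4, 6.7 percentage points apart, within the scatter of two such steps. This shows that, in these two pairs, the lengthening carried over from one core to the other, even though the pairs start from very different levels, with compound 1 at 49.5% and compound 3 at -1.6%. It does not show why the read-out falls, nor that the same step would appear on a third core or at other chain lengths, since it rests on two pairs only, each read at a single concentration, which gives the size of the effect there and not a potency.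

The compounds shown leave open whether a still longer chain, or a shorter one, would continue the same trend on either core. They also leave open what would happen with an amine or a carboxylic acid at the end of the chain in place of the present end group.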